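Cyclic sulfonylamidine series: liver microsome stability notes

The source may hold more compounds than are shown below. What is called first, only, known or untested is meant among the compounds shown, and "the series" means these compounds.

Measured compounds:
compound 1 `CS(=O)(=O)Nc1ccc2c(c1)S(=O)(=O)N=C(C1=C(O)C3CCCC3N(Cc3ccc(F)cn3)C1=O)N2`, 100%
compound 2 `Cc1cc(CN2C(=O)C(C3=NS(=O)(=O)c4cc(NS(C)(=O)=O)ccc4N3)=C(O)[C@H]3CCC[C@H]32)ccc1F`, 66%
compound 3 `CS(=O)(=O)Nc1ccc2c(c1)S(=O)(=O)N=C(C1=C(O)C3CCCCC3N(Cc3ccc(F)cc3)C1=O)N2`, 81%

In an ADME assay on microsomes from liver (Homo sapiens) for metabolic stability, with a stated time of 60 min, tested at 1 uM (on this read-out lower numbers stand for a less stable compound and higher numbers for a more stable compound), compound 1 gives 100%, compound 3 gives 81% and compound 2 gives 66%. Compound 2 stands lowest of the three; its gap to compound 3 and its larger gap to compound 1 both lie beyond the scatter.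

Compound 4 `CS(=O)(=O)Nc1ccc2c(c1)S(=O)(=O)N=C(C1=C(O)[C@H]3CCC[C@H]3N(CC3CC3)C1=O)N2` is not yet measured. It differs from compound 2 in one place: cyclopropyl in place of 4-fluoro-3-methylphenyl on a saturated chain carbon bound to an amide-type nitrogen in a ring. Among the compounds with values here, no step between measured compounds covers this change, so the direction is open. The expectation is a moderate gain in this assay, a step of a number 14 percentage points higher from compound 2 to compound 4 (beyond the scatter), with a return to the level of compound 3 or somewhat higher. Compound 4 is estimated at 80%, with a range from 60% to 98%.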

Compound 4, percent of the compound remaining: 99%
Beside the measured number, compound 4's estimate is 19 percentage points below it; measured number outside the range, above it.
By their numbers in this assay, from the lowest: compound 2; then compound 3; then compounds 4 and 1 (each within the scatter of the next).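

In this assay, cyclopropyl in place of 4-fluoro-3-methylphenyl on a saturated chain carbon bound to an amide-type nitrogen in a ring gives a number 33 percentage points higher from compound 2 to compound 4 (beyond the scatter). Within the data shown here, this is the first single-place comparison, and it shows that this position alone can move the read-out by a large step while the rest of compound 2 stays unchanged. Nothing at hand accounts for the step.

Still open, as far as these compounds go, is whether the aromatic ring itself or its fluoro and methyl substituents drive the difference. Also open, from the compounds shown here alone, is how a straight butyl chain or a chain ending in an amine would read at this position.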